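The compounds below may be only part of what the source reports. "The series", "measured", "known", "first", "only" and "open" are said of these compounds alone.

Two close relatives of a shared core have so far been tested in a functional assay on CHO-RD-HGA16 cells for agonist activity at Orexin/Hypocretin receptor type 1 (Homo sapiens), read by fluorescence and calcium flux, with a stated time of 30 min; on this read-out lower numbers stand for smaller maximal responses and higher numbers for larger maximal responses. Compound 1 `COc1ccc(-c2cncc(C(=O)N(C)C)c2)cc1S(=O)(=O)Nc1cccc(NCCNC(=O)c2cccc(C)c2)c1` gives 105% in this assay. Compound 2 `COc1ccc(-c2cccc(C(=O)N(C)CCN(C)C)c2)cc1S(=O)(=O)Nc1cccc(NCCNC(=O)c2cccc(C)c2)c1` gives 102% in this assay, the lower of the two numbers, though its gap to compound 1 lies within the usual scatter of repeated measurements, so the two cannot be told apart. Compound 3 `COc1ccc(-c2cccc(C(=O)N(C)Cc3ccccn3)c2)cc1S(=O)(=O)Nc1cccc(NCCNC(=O)c2cccc(C)c2)c1` has not yet been measured. It differs from compound 2 in one place: pyridin-2-yl in place of (dimethylamino)methyl on a saturated chain carbon bound to an amide-type nitrogen. Both measured compounds, which differ from each other in several places, reach a largest response close to the reference, so for this change no step beyond the scatter is expected in either direction. On that basis compound 3 is estimated to give 100% in this assay, within a range from 85% to 115%. The step this estimate means is expected to be a number 2 percentage points lower from compound 2 to compound 3 (within the scatter).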

Compound 3, largest response reached (Emax), in percent of the reference or control that the assay uses: 96%
Compound 3: the middle estimate sits 4 percentage points above what was measured, and the stated range covers the measured number.
By their numbers in this assay, from the lowest: compounds 3, 2 and 1 (each within the scatter of the next).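

Among these compounds, this is the first pair of compounds here that differ in one place only, so the group at the end of the amide side chain can be judged on its own. In this assay, putting pyridin-2-yl in place of (dimethylamino)methyl on a saturated chain carbon bound to an amide-type nitrogen gives a number 6 percentage points lower from compound 2 to compound 3 (within the scatter), so the two compounds cannot be told apart, even though a group with no ring gives way to a six-membered aromatic ring. Nothing available explains why this change leaves the two compounds indistinguishable.

As far as these compounds go, whether a carboxylic acid or a longer chain at this place would give a similar maximal response remains open. A plain phenyl ring at the same place would be needed to show whether the ring nitrogen of pyridin-2-yl matters.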